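The source may hold more compounds than are shown below. What is called first, only, known or untested is meant among the compounds shown, and "the series" means these compounds.

Compound 1 `CCCn1c(SCc2cc([N+](=O)[O-])ccc2OC)nc2cc(NC(=O)NC(C)(C)C)ccc21`: 120 nM
Compound 2 `CCCn1c(SCc2cc([N+](=O)[O-])ccc2OC)nc2cc(NC(=O)NC(C)(C)C)cc(C(=O)N(C)C)c21`: 200 nM
Compound 3 `CCCn1c(SCc2cc([N+](=O)[O-])ccc2OC)nc2cc(NC(=O)NC(C)(C)C)cc(C(=O)NCc3ccncc3)c21`: 35 nM

In an assay on isolated protein for inhibition of Gonadotropin-releasing hormone receptor (Rattus norvegicus) (on this read-out lower numbers stand for stronger inhibition and higher numbers for weaker inhibition), compound 3 stands lowest of the three numbers; the nearest is compound 1 at a 3.4-fold lower number from compound 1 to compound 3 (0.54 log units; beyond the scatter) and the furthest is compound 2 at a 5.7-fold lower number from compound 2 to compound 3 (0.76 log units; beyond the scatter). Compound 4 `CCCn1c(SCc2cc([N+](=O)[O-])ccc2OC)nc2cc(NC(=O)NC(C)(C)C)cc(C(=O)NCc3cccnc3)c21` differs from compound 3 only in the change (pyridin-3-yl in place of pyridin-4-yl on a saturated chain carbon bound to an amide-type nitrogen). Both measured steps toward compound 3 concern adding or swapping the whole group on the carbonyl carbon, and they were modest; none of them tests moving the ring nitrogen within the pyridinyl group alone. Compound 4 is therefore expected to stay close to compound 3, with a step of about a 1.1-fold higher number from compound 3 to compound 4 (0.06 log units; within the scatter), not beyond the scatter. The estimate for compound 4 in this assay is 40 nM, within 15 nM to 110 nM.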

Compound 4, half-maximal inhibitory concentration: 54 nM
Compound 4: the middle estimate sits 1.4-fold (0.13 log units) below what was measured, and the stated range covers the measured number.
By their numbers in this assay, from the lowest: compounds 3 and 4 (each within the scatter of the next); then compounds 1 and 2 (each within the scatter of the next).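

In this assay, pyridin-3-yl in place of pyridin-4-yl on the saturated chain carbon gives a step within the scatter (a 1.5-fold higher number from compound 3 to compound 4 (0.19 log units; within the scatter)), so this position tolerates the ring nitrogen in either of these two places. Compound 4 also keeps a lower number than the two compounds without a pyridine ring (a 3.7-fold lower number from compound 2 to compound 4 (0.57 log units; beyond the scatter)) and (a 2.2-fold lower number from compound 1 to compound 4 (0.35 log units; beyond the scatter)). No evidence here explains these steps. Still open, as far as these compounds go, are pyridin-2-yl at this place, a plain phenyl ring, and a longer chain between the amide nitrogen and the ring.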